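A Piperazine Replaces the Pyridinylamino Group

This account rests on a few compounds, and the source may have more. Where it says the series, first, only, none or still open, it means among the compounds named here.

Compound 1 `N#Cc1c(O)nc(SCc2nc3ccccc3[nH]2)nc1-c1ccccc1` gives 3.43 nM
Compound 2 `N#Cc1c(Nc2ccccn2)nc(SCc2nc3ccccc3[nH]2)nc1-c1ccccc1` gives 8.9 nM

Both compounds were tested in a functional assay on G-361 cells (Homo sapiens) for cytotoxicity, read by MTT assay, with a stated time of 3 days; on this read-out lower numbers stand for stronger inhibition and higher numbers for weaker inhibition. Of the two numbers, the higher belongs to compound 2 at 8.9 nM. The change now followed is piperazin-1-yl in place of (pyridin-2-yl)amino on an aromatic carbon, which gives compound 3 `N#Cc1c(-c2ccccc2)nc(SCc2nc3ccccc3[nH]2)nc1N1CCNCC1`, with piperazin-1-yl in place of (pyridin-2-yl)amino on an aromatic carbon. For the measured compounds named here, one measured step bears on this place: a 2.6-fold higher number from compound 1 to compound 2 (0.41 log units; beyond the scatter), modest but beyond the scatter. Going by the values given here, no measured compound carries piperazin-1-yl, so the data set no direction for the change. A step no larger than that modest one is expected in this assay, and quite possibly none beyond the scatter. The step expected is a 1.1-fold lower number from compound 2 to compound 3 (0.05 log units; within the scatter). Compound 3 is estimated at 8 nM, with an expected range of 2.5 nM to 28 nM.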

Compound 3, half-maximal inhibitory concentration: 2.5 nM
Estimate against measurement, compound 3: 3.2-fold (0.51 log units) above; low and high end bracket the measured number.
By their numbers in this assay, from the lowest: compounds 3 and 1 (each within the scatter of the next); then compound 2.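

For the compounds shown here, at this position, ortho to a cyano group, the earlier compounds showed only a rise in the number when (pyridin-2-yl)amino stood in place of hydroxy. In this assay, piperazin-1-yl now gives a 3.6-fold lower number from compound 2 to compound 3 (0.55 log units; beyond the scatter), so a nitrogen-linked ring here need not carry that rise, and against hydroxy the change gives a 1.4-fold lower number from compound 1 to compound 3 (0.14 log units; within the scatter), which leaves those two groups indistinguishable on this read-out. Nothing available explains why these two nitrogen-linked rings differ.

The compounds shown leave open whether the result belongs to piperazin-1-yl in particular or would extend to morpholin-4-yl, 4-methylpiperazin-1-yl or an open-chain amine such as dimethylamino. They also leave open how a simple methoxy group or an unsubstituted amino group would compare with hydroxy at this place.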